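This account rests on a few compounds, and the source may have more. Where it says the series, first, only, none or still open, it means among the compounds named here.

Working notes on the series. In a functional assay on HL-60 cells (Homo sapiens) for inhibition, read by MTT assay, with a stated time of 72 h (a higher number here means a weaker inhibitor, a lower number a stronger inhibitor), compound 1 (`Cc1nc(-c2ccc(F)cc2)c(C(=O)N2CCN(c3cc(Cl)cc(Cl)c3)CC2)o1`) gives 52.1 nM. In this assay, compound 2 (`Cc1nc(-c2ccc(F)cc2)c(C(=O)N2CCN(c3ccc(Cl)cc3)CC2)o1`) is reported as "not active" (no number reported), so it stands without a number and offers no value from which to measure a step. Compound 3 is `COc1cccc(N2CCN(C(=O)c3oc(C)nc3-c3ccc(F)cc3)CC2)c1`. The structural change is 3-methoxyphenyl in place of 4-chlorophenyl on an amine nitrogen in a ring, with 3-methoxyphenyl in place of 4-chlorophenyl on an amine nitrogen in a ring. With no number for compound 2, the size of the step cannot be fixed. The expected direction in this assay is towards stronger inhibition, from no number to a measurable value, though a second inactive result remains possible. The expected result still lies on the weaker side of compound 1 at 52.1 nM. For compound 3 the estimated value is 400 nM, with an expected range of 60 nM to 5000 nM.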

Compound 3, half-maximal inhibitory concentration: 112 nM
Compound 3: the middle estimate sits 3.6-fold (0.55 log units) above what was measured; measured number inside the range.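

In this assay, compound 3 shows that a measurable value at this place, on an amine nitrogen in a ring, does not depend on chlorine: 3-methoxyphenyl in place of 3,5-dichlorophenyl gives only a modest loss (a 2.1-fold higher number from compound 1 to compound 3 (0.33 log units; beyond the scatter)). Compound 2, with 4-chlorophenyl at the same place, has no number, so the step to compound 3 cannot be read, and chlorine alone does not separate the measured compounds from the inactive one. Nothing at hand accounts for the differences among these three aryl groups.

The compounds shown leave open whether the methoxy group itself contributes or whether an unsubstituted phenyl would give a similar value. They also leave open how a hydroxyl or a nitrile on the same ring would compare with 3-methoxyphenyl and 3,5-dichlorophenyl on the shared core.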